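Removing the chloro from compound 1: what to expect

The source may hold more compounds than are shown below. What is called first, only, known or untested is meant among the compounds shown, and "the series" means these compounds.

In a functional assay on SK-OV-3 cells (Homo sapiens) for inhibition (on this read-out lower numbers stand for stronger inhibition of growth and higher numbers for weaker inhibition of growth), compound 1 `COc1cc(/C=C/C(=O)c2cccc(-n3cc(-c4ccc(Cl)cc4)[nH]c3=O)c2)cc(OC)c1OC` gives 31400 nM, the higher of the two numbers obtained so far. Compound 2 `O=C(/C=C/c1cccc(O)c1)c1cccc(-n2cc(-c3ccccc3)[nH]c2=O)c1` differs from it in several places and gives 11100 nM in this assay, a smaller number that lies beyond the scatter; what part of the gap belongs to which change cannot be told from these two compounds alone.

Within the data shown here, compound 3 `COc1cc(/C=C/C(=O)c2cccc(-n3cc(-c4ccccc4)[nH]c3=O)c2)cc(OC)c1OC` is the first single-point step from compound 1: hydrogen in place of chloro on an aromatic carbon, on an aromatic carbon of a six-membered aromatic ring of carbon only, para to a large group. Among the measured compounds shown here, no measured pair shows this change on this core, so the size of its effect in this assay is unknown. The step from compound 1 to compound 3 is expected to be small, a 1.4-fold lower number from compound 1 to compound 3 (0.15 log units; within the scatter), most likely not beyond the scatter. Compound 3 is therefore estimated at 22000 nM, with a range from 8000 nM to 60000 nM.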

Compound 3, concentration for 50% growth inhibition: 3270 nM
Compound 3: middle estimate off by 6.7-fold (0.83 log units), on the high side, outside the stated range (below it).
By their numbers in this assay, from the lowest: compound 3; then compound 2; then compound 1.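

In this assay the change from 4-chlorophenyl to phenyl brings a 9.6-fold lower number from compound 1 to compound 3 (0.98 log units; beyond the scatter) on the shared core. The earlier compounds shown here differed in several places and could not assign any part of their gap to one change, whereas this single exchange of chloro for hydrogen, para to a large group, shows that this position alone moves growth inhibition beyond the scatter, with the hydrogen compound the stronger inhibitor of the pair. Nothing available explains why this exchange has so large an effect.

Going by these compounds, whether the step is specific to chloro or would appear with any other group at this place remains open, and a fluoro, a methyl or an amine there would test that. On these data alone, it is also open whether the step carries over to a different core.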